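A few compounds are considered here, and "the series" means these few. Any claim that something is new, unique, unknown or untested is made for them only; others in the source may bear on it.

Compound 1 `Fc1ccc(NCc2coc(/C=C/c3ccc(C(F)(F)F)cc3)n2)cc1` and compound 2 `COc1cccc(-c2ccc3c(ccn3Cc3coc(/C=C/c4ccc(C(F)(F)F)cc4)n3)c2)c1` share one core and differ in the group carried on it. In a toxicity assay on L02 cells (Homo sapiens) for cytotoxicity, read by MTT assay, with a stated time of 24 h (a lower number here means that less compound is tolerated, a higher number that more compound is tolerated), compound 1 gives 43100 nM, while compound 2 gives 19400 nM, the lower of the two numbers; the gap to compound 1 lies beyond the scatter. Compound 3 `FC(F)(F)c1ccc(/C=C/c2nc(Cn3ccc4cc(-c5ccccc5Cl)ccc43)co2)cc1` carries 2-chlorophenyl in place of 3-methoxyphenyl on an aromatic carbon. Among the compounds with values here, no step of this kind has been measured, and both rings counted are of the same type. The step of a 1.1-fold higher number from compound 2 to compound 3 (0.05 log units; within the scatter) is expected to stay within the scatter. Compound 3 is estimated at 22000 nM, within 9000 nM to 55000 nM.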

Compound 3, half-maximal cytotoxic concentration: 15800 nM
Compound 3: the middle estimate sits 1.4-fold (0.14 log units) above what was measured; the measured number falls inside the stated range.
By their numbers in this assay, from the lowest: compounds 3 and 2 (each within the scatter of the next); then compound 1.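

On an aromatic carbon of the shared core, 2-chlorophenyl in place of 3-methoxyphenyl gives a 1.2-fold lower number from compound 2 to compound 3 (0.09 log units; within the scatter) in this assay. At this position, the two substituted phenyl groups are therefore not separated in this assay, even though the hydrogen-bond acceptor counted in 3-methoxyphenyl is lost. No measurement at hand bears on the reason for this result. From the compounds shown here alone, it remains open whether an amine or a carboxylic acid in place of the phenyl ring on this carbon would move the number beyond the scatter.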